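This account rests on a few compounds, and the source may have more. Where it says the series, first, only, none or still open, it means among the compounds named here.

Measured in a functional assay on the whole organism for agonist activity, with Mus musculus as the target; on this read-out higher numbers stand for an effect only at larger amounts of compound and lower numbers for an effect already at smaller amounts:
Compound 1 `CC(=O)N(C)C(C)C#CCn1cncc1C`: > 100 mg/kg
Compound 2 `COC(=O)N(C)C(C)C#CCN(C)C`: 11.8 mg/kg
Compound 3 `O=C1OCCN1CC#CCn1ccnc1`: 3 mg/kg

The value of compound 1 is a limit and not a number. That leaves two numbers to compare in this assay. Compound 3 has the lower of the two, and compound 2 lies higher by a gap beyond the scatter, so an effect appears at smaller amounts of compound 3.

Next in the series is compound 4 `Cc1cncn1CC#CCN1CCOC1=O`. It keeps the structure of compound 3 but carries methyl in place of hydrogen on an aromatic carbon of the five-membered aromatic ring with 2 nitrogen (methyl in place of hydrogen on an aromatic carbon). For the measured compounds named here, no measured pair isolates this change, so the expectation rests on thin ground. Going by the values given here, the only hint comes from compound 1, which carries the same methyl on the same ring and reads > 100 mg/kg. Compound 1 also differs from compound 4 elsewhere, so this hint is weak and does not fix the size of the step. A move towards a higher number, beyond the scatter, is expected, and the estimated step is a 5.0-fold higher number from compound 3 to compound 4 (0.70 log units; beyond the scatter). For compound 4 the expected value is 15 mg/kg, with an estimated range of 3 mg/kg to 80 mg/kg.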

Compound 4, dose for half-maximal effect: 30 mg/kg
Estimate against measurement, compound 4: 2.0-fold (0.30 log units) below; the measured number falls inside the stated range.
By their numbers in this assay, from the lowest: compound 3; then compound 2; then compound 4. At a limit, above all of these: compound 1.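

In this assay, for the compounds shown here, the change at this place gives a 10-fold higher number from compound 3 to compound 4 (1.00 log units; beyond the scatter), and this is the first measured pair that isolates methyl in place of hydrogen on an aromatic carbon. In this pair, a group of 1 heavy atom, on the carbon next to the ring atom that bears a large group, is enough to move the number beyond the scatter, so this carbon of the five-membered aromatic ring with 2 nitrogen is not indifferent to substitution. Compound 4 still gives a true number, whereas compound 1 carries the same methyl but also differs elsewhere, so no step can be read to it, and its value is a limit: the limit of > 100 mg/kg in this assay, at which 1 of the 4 values shown sits.

Still open, going by these compounds, is whether a longer chain such as ethyl, or a single chlorine atom, on the same carbon would push the number further or pull it back, and whether methyl on the other ring carbons would act in the same way. One pair also cannot tell whether the step carries over when a dimethylamino group or another amine takes the place of the ring at the far end of the chain.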